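A few compounds are considered here, and "the series" means these few. Any claim that something is new, unique, unknown or untested is made for them only; others in the source may bear on it.

In an assay on CHO cells for antagonist activity at transient receptor potential cation channel subfamily V member 1 (Homo sapiens), read by FLIPR (a lower number here means a stronger inhibitor, a higher number a weaker inhibitor), compound 1 `CC1CCN(c2cc(C(F)(F)F)ccc2CNC(=O)C(C)c2ccc(NS(C)(=O)=O)c(F)c2)CC1` gives 0.9 nM, level with compound 2 `CC(C(=O)NCc1ccc(C(F)(F)F)cc1N1CCC(c2ccc(F)cc2)CC1)c1ccc(NS(C)(=O)=O)c(F)c1`, which gives 0.9 nM in this assay. Among the compounds with values here, the only step that bears here, no change at the digits printed from compound 1 to compound 2 (within the scatter), put 4-fluorophenyl in place of methyl on a saturated ring carbon and left potency unchanged within the scatter. Compound 3 `CC(C(=O)NCc1ccc(C(F)(F)F)cc1N1CCN(C2CCCCC2)CC1)c1ccc(NS(C)(=O)=O)c(F)c1` differs from compound 1 by 4-cyclohexylpiperazin-1-yl in place of 4-methylpiperidin-1-yl on an aromatic carbon, a larger change that also alters the saturated ring itself, so a modest loss beyond the scatter is expected, a 3.3-fold higher number from compound 1 to compound 3 (0.52 log units; beyond the scatter). Compound 3 is therefore estimated at 3 nM, between 0.7 nM and 15 nM.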

Compound 3, inhibition constant: 13.8 nM
The estimate for compound 3 lay 4.6-fold (0.66 log units) below the measured number; the measured number falls inside the stated range.
By their numbers in this assay, from the lowest: compounds 1 and 2 (each within the scatter of the next); then compound 3.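

In this assay, the change at this aromatic carbon gives a 15-fold higher number from compound 1 to compound 3 (1.19 log units; beyond the scatter) and so counts as a large loss, which the earlier step, with no change at the digits printed from compound 1 to compound 2 (within the scatter) as its result, gave no sign of. A larger group here is therefore not always tolerated, since the 4-fluorophenyl of compound 2 held potency and the 4-cyclohexylpiperazin-1-yl of compound 3 did not. No evidence at hand accounts for this loss.

The step brings in a second ring nitrogen and a cyclohexyl ring together, and the compounds shown cannot separate the two. As far as these compounds go, whether 4-cyclohexylpiperidin-1-yl or 4-methylpiperazin-1-yl would keep the potency of compound 1 remains open.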